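The source may hold more compounds than are shown below. What is called first, only, known or untested is meant among the compounds shown, and "the series" means these compounds.

Measured compounds:
compound 1, `CC(C)c1cccc(C(C)C)c1NC(=O)NCC1(c2cccc(N(C)C)c2)CCCC1` — 33 nM
compound 2, `CC(C)c1cccc(C(C)C)c1NC(=O)NCC1(c2ccc(NCCO)cc2)CCCC1` — 25 nM

The two measured compounds share one core and differ only in the aryl group on the saturated ring carbon of the five-membered non-aromatic ring of carbon only. In an assay on microsomes for inhibition of acyl-CoA:cholesterol acyltransferase (Oryctolagus cuniculus) (on this read-out lower numbers stand for stronger inhibition and higher numbers for weaker inhibition), compound 2 gives 25 nM, the lower of the two numbers, and compound 1 gives 33 nM; the step of a 1.3-fold lower number from compound 1 to compound 2 (0.12 log units; within the scatter) lies within the scatter. Compound 3 `CC(C)c1cccc(C(C)C)c1NC(=O)NCC1(c2cccc(CO)c2)CCCC1` has not been measured in this assay. It differs from compound 2 in one place: 3-(hydroxymethyl)phenyl in place of 4-((2-hydroxyethyl)amino)phenyl on a saturated ring carbon. Within the data shown here, the only measured step that bears on this change is the one from compound 1 to compound 2, which exchanged one aryl substituent for another and stayed within the scatter. On that basis compound 3 is expected to sit close to compound 2, with the step of a 1.2-fold higher number from compound 2 to compound 3 (0.08 log units; within the scatter) not beyond the scatter. The estimate for compound 3 in this assay is 30 nM, within a range from 10 nM to 90 nM.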

Compound 3, half-maximal inhibitory concentration: 15 nM
The estimate for compound 3 lay 2.0-fold (0.30 log units) above the measured number; the range from low to high includes it.
By their numbers in this assay, from the lowest: compounds 3, 2 and 1 (each within the scatter of the next, the first and the last beyond it).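

In this assay, among these compounds, hydroxymethyl in place of dimethylamino on an aromatic carbon gives the first step in this set that clears the scatter (a 2.2-fold lower number from compound 1 to compound 3 (0.34 log units; beyond the scatter)), though only modestly. Set against the 4-((2-hydroxyethyl)amino)phenyl group, the 3-(hydroxymethyl)phenyl group gives a smaller step that stays within the scatter (a 1.7-fold lower number from compound 2 to compound 3 (0.22 log units; within the scatter)), so these two aryl groups cannot be told apart here, even though the one that enters has fewer heavy atoms and no nitrogen. Nothing at hand accounts for either step.

As far as these compounds go, it remains open whether a carboxylic acid or a primary amine in place of hydroxymethyl on that aromatic carbon would hold the number at this level. Also open, from the compounds shown here alone, is how much the place of the substituent on the aryl ring counts, as compound 2 and compound 3 differ in both the substituent and its place.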